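A Trifluoromethyl Swap Tested on Two Different Cores

The source may report more compounds than this note shows. Statements on the series, on what has been measured and on what is new or still open speak of the compounds shown alone.

Compound 1 `C=C1C(=O)[C@]23C[C@@]1(O)CC[C@H]2c1ccc(O)c(C)c1[C@@H]3Cn1cc(-c2ccc(F)cc2)nn1` — 250 nM
Compound 2 `C=C1C(=O)[C@]23C[C@@]1(O)CC[C@H]2c1ccc(O)c(C)c1[C@@H]3Cn1cc(-c2ccc(C(F)(F)F)cc2)nn1` — 370 nM
Compound 3 `C=C1C[C@]23C[C@@]1(O)CC[C@@H]2c1cccc(C)c1[C@@H]3Cn1cc(-c2ccc(F)cc2)nn1` — > 20000 nM, a limit of the assay rather than a number

Compound 1 was tested in a functional assay on SW480 cells (Homo sapiens) for cytotoxicity, read by MTT assay, with a stated time of 4 days (a higher number here means a weaker inhibitor, a lower number a stronger inhibitor), where compound 1 gives 250 nM. Compound 2 differs from it by trifluoromethyl in place of fluoro on an aromatic carbon, and in this assay compound 2 gives 370 nM. The measured step is a 1.5-fold higher number from compound 1 to compound 2 (0.17 log units; within the scatter), so the swap on this core leaves the result where it was.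

Compound 3 carries a different core. In this assay compound 3 reaches only > 20000 nM, which is a limit of the assay and not a number, as recorded by the limit of > 20000 nM in this assay, at which 1 of the 3 values shown sits. How the core of compound 3 differs from the core of compound 1 is not broken down here.

Compound 4 `C=C1C[C@]23C[C@@]1(O)CC[C@@H]2c1cccc(C)c1[C@@H]3Cn1cc(-c2ccc(C(F)(F)F)cc2)nn1` stands to compound 3 as compound 2 stands to compound 1: the difference is trifluoromethyl in place of fluoro on an aromatic carbon, and the two places read the same word for word, so it is the same change.

The expected step for compound 4 is a step that the limit leaves unreadable from compound 3 to compound 4, estimated to be small. This expectation rests on the step of a 1.5-fold higher number from compound 1 to compound 2 (0.17 log units; within the scatter) lying within the scatter. It also rests on compound 3 sitting at a limit, > 20000 nM. Compound 4 is therefore expected to give about 30000 nM in this assay. For compound 4 the estimate spans 12000 nM to 80000 nM, with the result most likely again reported only as a limit.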

Compound 4, half-maximal inhibitory concentration: > 20000 nM
Compound 4 was reported as a limit; the forecaster's own chance of this, stated with the estimate: 85%; the middle value is on the limit's open side.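

In this assay compound 4 gives > 20000 nM, which is a limit of the assay and not a number. Compound 3 stands at a limit too, so no step can be read between compound 3 and compound 4: the limit of > 20000 nM in this assay, at which 2 of the 4 values shown sit. The compounds shown leave open whether trifluoromethyl in place of fluoro changes the result on the core of compound 3 at all.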